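Series notes: solubility of the cyclic carbamate ureas

This account rests on a few compounds, and the source may have more. Where it says the series, first, only, none or still open, it means among the compounds named here.

Of the compounds shown here, three have been measured in a physicochemical assay for solubility, read by HPLC, in phosphate buffer, measured as kinetic solubility, with a stated time of 1 h, at pH 7.4, tested at 250 uM; a lower number here means a less soluble compound, a higher number a more soluble compound. Compound 1 `CC(C)CNC(=O)n1c(=O)oc2cc(C3CCN(C)CC3)ccc21` gives 240000 nM in this assay. Compound 2 `O=C(NCCCCc1ccccc1)n1c2c(oc1=O)CNCC2`, which carries a different saturated core, gives 230000 nM. Compound 3 `CN1CCC(c2ccc3c(c2)oc(=O)n3C(=O)NCCOCc2ccccc2)CC1` gives 73000 nM, the lowest of the three numbers; the gap to compound 2 and the gap to compound 1 both lie beyond the scatter.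

One single-point step is known: a 3.3-fold lower number from compound 1 to compound 3 (0.52 log units; beyond the scatter). Compound 4 `CN1CCC(c2ccc3c(c2)oc(=O)n3C(=O)NCCCCc2ccccc2)CC1` is not yet measured. It differs from compound 3 as follows: phenethyl in place of benzyloxy on a saturated chain carbon, two bonds along the chain from an amide-type nitrogen. Within the data shown here, no measured pair shows this exchange of an ether-bearing chain for an all-carbon chain of the same length, so the known step from compound 1 to compound 3 bears on it only indirectly, in that the side chain on the amide-type nitrogen has already moved the number by a modest amount. Compound 2 shares the 4-phenylbutyl chain of compound 4 but not its core, so its value can only be noted, not used as a step.

Given no directly relevant step, the expectation for compound 4 is a step of a 1.3-fold lower number from compound 3 to compound 4 (0.12 log units; within the scatter) in this assay, within or near the scatter. Compound 4 is therefore estimated at 55000 nM, with a range from 22000 nM to 140000 nM.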

Compound 4, solubility: 120000 nM
Compound 4: the middle estimate sits 2.2-fold (0.34 log units) below what was measured; low and high end bracket the measured number.
By their numbers in this assay, from the lowest: compounds 3, 4, 2 and 1 (each within the scatter of the next, the first and the last beyond it).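

In this assay the exchange of benzyloxy for phenethyl on the saturated chain carbon, two bonds along the chain from an amide-type nitrogen, keeps the count of 8 heavy atoms and removes the hydrogen-bond acceptor, and it gives a 1.6-fold higher number from compound 3 to compound 4 (0.22 log units; within the scatter); on this evidence, replacing the ether oxygen with carbon at this position has no effect that can be told from the scatter. The comparison with the isopropyl chain also gains a second point: 3-phenylpropyl in place of isopropyl gives a 2.0-fold lower number from compound 1 to compound 4 (0.30 log units; within the scatter), whereas (benzyloxy)methyl gave a 3.3-fold lower number from compound 1 to compound 3 (0.52 log units; beyond the scatter), so a long chain ending in a phenyl ring does not by itself bring a step beyond the scatter, although the closeness of compound 3 and compound 4 makes this a thin distinction. No measurement at hand offers an explanation for these numbers.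

Going by these compounds, whether an amine or a carboxylic acid on this chain, or a longer chain, would give a step beyond the scatter stays open. Among these compounds, also open is whether the exchange of benzyloxy for phenethyl would read the same on a core other than the one shared by compound 3 and compound 4.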